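Notes on replacing 1,3-oxazol-5-yl with 1-methylimidazolyl

The compounds below may be only part of what the source reports. "The series", "measured", "known", "first", "only" and "open" are said of these compounds alone.

Compound 3 `Nc1nc(-c2cnco2)nc2sc(Cc3ccccc3)cc12` is the reference point of this short series. Going by the values given here, in a functional assay on CHO-K1 cells for antagonist activity at adenosine receptor A1 (Homo sapiens), read by a beta-galactosidase reporter and cAMP accumulation, with stated times of 15 min and 6 h (a higher number here means a weaker inhibitor, a lower number a stronger inhibitor), compound 3 gives 106 nM, the lowest of the three numbers measured so far. Compound 2 `Nc1nc(C2CCCO2)nc2sc(Cc3ccccc3)cc12` carries oxolan-2-yl at the same aromatic carbon; in this assay compound 2 gives 2950 nM. Compound 1 `N#Cc1ccc(-c2nc(N)c3cc(Cc4ccccc4)sc3n2)o1` carries 5-cyanofuran-2-yl there; in this assay compound 1 gives 3160 nM. The two steps that lead to compound 3 are large: a 30-fold lower number from compound 1 to compound 3 (1.47 log units; beyond the scatter) and a 28-fold lower number from compound 2 to compound 3 (1.44 log units; beyond the scatter). Between the other two compounds the step is small: a 1.1-fold lower number from compound 1 to compound 2 (0.03 log units; within the scatter).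

Compound 4 `Cn1cnc(-c2nc(N)c3cc(Cc4ccccc4)sc3n2)c1` is not yet measured. It differs from compound 3 in one place: 1-methyl-1H-imidazol-4-yl in place of 1,3-oxazol-5-yl on an aromatic carbon. The measured steps show only that 1,3-oxazol-5-yl gives a far lower number than 5-cyanofuran-2-yl or oxolan-2-yl; none of them tests a second five-membered aromatic ring with 2 hetero atoms against the first. The entering group, like the leaving one, is a five-membered aromatic ring with 2 hetero atoms and 2 hydrogen-bond acceptors, with a methyl added. For compound 4 in this assay the expected step is therefore a modest move toward a higher number, near the edge of the scatter, a 2.4-fold higher number from compound 3 to compound 4 (0.37 log units; beyond the scatter). Compound 4 is estimated at 250 nM, with a range from 60 nM to 1200 nM.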

Compound 4, inhibition constant: 2330 nM
For compound 4 the middle estimate is 9.3-fold (0.97 log units) below the measured one; measured number above the stated range.
By their numbers in this assay, from the lowest: compound 3; then compounds 4, 2 and 1 (each within the scatter of the next).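

In this assay there is a 22-fold higher number from compound 3 to compound 4 (1.34 log units; beyond the scatter), so at this aromatic carbon, keeping a five-membered aromatic ring with 2 hetero atoms and the same count of hydrogen-bond acceptors is not enough to retain the low number of compound 3. With a 1.3-fold lower number from compound 2 to compound 4 (0.10 log units; within the scatter) and a 1.4-fold lower number from compound 1 to compound 4 (0.13 log units; within the scatter), the 1-methyl-1H-imidazol-4-yl group falls in with the oxolan-2-yl and 5-cyanofuran-2-yl groups, and among the four compounds the low number belongs to the 1,3-oxazol-5-yl group of compound 3 alone. Nothing available on these compounds gives a reason for the size of the step from the 1,3-oxazol-5-yl group to the 1-methyl-1H-imidazol-4-yl group.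

This single change replaces the ring oxygen with nitrogen, adds a methyl and alters the ring's point of attachment, and the compounds shown do not separate these differences. Going by these compounds, whether an imidazolyl ring without the methyl, a 1,3-thiazol-5-yl ring or a methyl-bearing 1,3-oxazol-5-yl ring would stay close to compound 3 or fall in with compound 4 remains open.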